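The source may hold more compounds than are shown below. What is called first, only, known or untested is meant among the compounds shown, and "the series" means these compounds.

Compound 2 `Cn1c(=O)c(=O)n(C2CCCC2)c2nc(N/N=C/c3ccc(F)c(Cl)c3)ncc21` and compound 1 `Cc1cccc(/C=N/Nc2ncc3c(n2)n(C2CCCC2)c(=O)c(=O)n3C)c1` share one core and differ only in the group on the carbon with a double bond to nitrogen. In a functional assay on PC-3 cells (Homo sapiens) for antiproliferative activity, read by MTT assay (on this read-out lower numbers stand for stronger inhibition and higher numbers for weaker inhibition), compound 1 gives 53600 nM, and in this assay compound 2 gives 8550 nM. Among the measured compounds shown here, the single measured step, a 6.3-fold lower number from compound 1 to compound 2 (0.80 log units; beyond the scatter), shows that the group at this position moves the number well beyond the scatter. For the measured compounds named here, compound 2 therefore stands as the lowest of the two numbers known, with compound 1 as its only neighbour.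

Compound 3 `Cn1c(=O)c(=O)n(C2CCCC2)c2nc(N/N=C/c3ccco3)ncc21` is not yet measured. Its change from compound 2 is furan-2-yl in place of 3-chloro-4-fluorophenyl on a carbon with a double bond to nitrogen. Going by the values given here, no measured step bears directly on this exchange: the only step known, from compound 1 to compound 2, concerns a change between two six-membered aromatic rings of carbon only, not the entry of a five-membered ring with one hetero atom. Because a 6.3-fold lower number from compound 1 to compound 2 (0.80 log units; beyond the scatter) was modest but real, the expectation is that the number will move again, and the expected step is a 2.9-fold higher number from compound 2 to compound 3 (0.47 log units; beyond the scatter) in this assay, toward a higher number. For compound 3 the estimate in this assay is 25000 nM, with a range from 6000 nM to 100000 nM.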

Compound 3, half-maximal inhibitory concentration: 72200 nM
Compound 3: middle estimate off by 2.9-fold (0.46 log units), on the low side, within the range that was stated.
By their numbers in this assay, from the lowest: compound 2; then compounds 1 and 3 (each within the scatter of the next).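

The step of an 8.4-fold higher number from compound 2 to compound 3 (0.93 log units; beyond the scatter) in this assay shows that the lower number of compound 2 does not survive the exchange of 3-chloro-4-fluorophenyl for furan-2-yl on a carbon with a double bond to nitrogen. The step of a 1.3-fold higher number from compound 1 to compound 3 (0.13 log units; within the scatter) adds what the first pair could not show: a five-membered aromatic ring with one hetero atom and the 3-methylphenyl group of compound 1 give readings that cannot be told apart, so that, of the three groups, only 3-chloro-4-fluorophenyl stands clear of the others, beyond the scatter from both. No independent measurement accompanies these numbers to account for the difference between the groups.

The compounds shown leave open whether the lower number needs both halogens, which a phenyl ring carrying chlorine alone or fluorine alone would test, and whether an unsubstituted phenyl ring would read with compound 2 or with the other two. They also leave open how other five- and six-membered rings, such as thiophene or pyridine, would read at this position, and whether an amine or a carboxylic acid on the ring would be tolerated there.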